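A few compounds are considered here, and "the series" means these few. Any claim that something is new, unique, unknown or untested is made for them only; others in the source may bear on it.

Measured in a functional assay on DLD-1 cells (Homo sapiens) for cytotoxicity, with a stated time of 48 h; on this read-out lower numbers stand for stronger inhibition and higher numbers for weaker inhibition:
- compound 1 `CCOc1ccc2oc(/C=C/[S+](C)[O-])cc(=O)c2c1`: 4900 nM
- compound 2 `C[S+]([O-])/C=C/c1cc(=O)c2ccccc2o1`: 8000 nM
- compound 3 `Cc1ccc2oc(/C=C/[S+](C)[O-])cc(=O)c2c1`: 7000 nM

These three values cannot be told apart. Compound 3 stands close to both of the others, with a 1.1-fold lower number from compound 2 to compound 3 (0.06 log units; within the scatter) and a 1.4-fold higher number from compound 1 to compound 3 (0.15 log units; within the scatter).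

The next structure, compound 4 `CCC(=O)Oc1ccc2oc(/C=C/[S+](C)[O-])cc(=O)c2c1`, has propanoyloxy in place of methyl on an aromatic carbon. Going by the values given here, no measured compound carries propanoyloxy, so the evidence is indirect. Among the compounds with values here, the steps that bear on this change are those at the same aromatic carbon. Replacing ethoxy with hydrogen gave a 1.6-fold higher number from compound 1 to compound 2 (0.21 log units; within the scatter), replacing ethoxy with methyl gave a 1.4-fold higher number from compound 1 to compound 3 (0.15 log units; within the scatter), and replacing hydrogen with methyl gave a 1.1-fold lower number from compound 2 to compound 3 (0.06 log units; within the scatter). None of these exceeds the scatter, so no step beyond the scatter is expected in this assay, though the untested group leaves the direction uncertain and calls for a wide range.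

The expected step is a 1.3-fold lower number from compound 3 to compound 4 (0.10 log units; within the scatter).

For compound 4 the estimate is 5500 nM, with an expected range of 2500 nM to 12000 nM.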

Compound 4, half-maximal inhibitory concentration: 9000 nM
For compound 4 the middle estimate is 1.6-fold (0.21 log units) below the measured one, and the stated range covers the measured number.
By their numbers in this assay, from the lowest: compounds 1, 3, 2 and 4 (each within the scatter of the next).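

Among the compounds shown, propanoyloxy is the first group at this aromatic carbon with a double bond outside the aromatic rings and hydrogen-bond acceptors counted for it, and it brings five heavy atoms where methyl has one. Yet in this assay the change stays within the scatter (a 1.3-fold higher number from compound 3 to compound 4 (0.11 log units; within the scatter)), as does the comparison with hydrogen at this carbon (a 1.1-fold higher number from compound 2 to compound 4 (0.05 log units; within the scatter)) and the exchange of ethyl for propanoyl on the oxygen on the aromatic ring (a 1.8-fold higher number from compound 1 to compound 4 (0.26 log units; within the scatter)). Nothing measured accounts for this lack of a resolved difference.

Going by these compounds, it remains open whether an amine or a carboxylic acid at this aromatic carbon would give a step beyond the scatter. The same holds for a longer acyl chain in place of propanoyl.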